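A few compounds are considered here, and "the series" means these few. Any claim that something is new, unique, unknown or untested is made for them only; others in the source may bear on it.

For the measured compounds named here, compound 1 `Cc1[nH]c2ccccc2c1C1=CCNCC1` stands as the higher of the two numbers measured so far: in an assay on HEK293 cells for displacement of a labelled ligand from 5-hydroxytryptamine receptor 6 (Homo sapiens), read by scintillation counting, with a stated time of 1 h (a lower number here means a stronger inhibitor, a higher number a weaker inhibitor), compound 1 gives 200 nM. Compound 2 `Cc1[nH]c2ccc(Oc3ccccc3[N+](=O)[O-])cc2c1C1=CCNCC1`, which carries a nitrophenoxy group on the shared core, gives 9 nM in this assay, and the gap between the two lies well beyond the scatter. The next compound, compound 3 `Cc1[nH]c2ccc(OC(C)C)cc2c1C1=CCNCC1`, differs from compound 1 in one place: isopropoxy in place of hydrogen on an aromatic carbon. Going by the values given here, no measured pair shows this exact change, so the expectation rests on compound 2, whose 9 nM shows that an oxygen-linked group on the core can go with a much lower number. A smaller oxygen-linked group is expected to lower the number too, though more modestly, so the step from compound 1 to compound 3 is estimated at a 4.0-fold lower number from compound 1 to compound 3 (0.60 log units; beyond the scatter). For compound 3 the expected value in this assay is 50 nM, with a range from 15 nM to 160 nM.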

Compound 3, half-maximal inhibitory concentration: 100 nM
Beside the measured number, compound 3's estimate is 2.0-fold (0.30 log units) below it; measured number inside the range.
By their numbers in this assay, from the lowest: compound 2; then compounds 3 and 1 (each within the scatter of the next).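

In this assay, isopropoxy in place of hydrogen on an aromatic carbon of the shared core goes with a 2.0-fold lower number from compound 1 to compound 3 (0.30 log units; within the scatter) and so, at this position, this group cannot be told apart from hydrogen. An oxygen link on the core is thus not enough on its own to bring a number like that of compound 2, at 9 nM in this assay, since compound 3 stands at 100 nM in the same assay. Nothing at hand speaks to what lies behind this result.

Still open, on these data alone, is whether a plain phenoxy group without the nitro group, or a methoxy group or longer alkoxy chain, would give a number closer to that of compound 2 or to that of compound 1. An amine or a carboxylic acid on the same aromatic carbon is also an open case.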